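This account rests on a few compounds, and the source may have more. Where it says the series, first, only, none or still open, it means among the compounds named here.

Measured so far: compound 1 `Cc1nn(C2COC2)cc1Nc1nc(N)c2c(C#N)c(N3CCC[C@H]3C)n(C)c2n1` and compound 2 `Cc1c(Nc2nc(N)c3c(C#N)c(N4CCC[C@H]4C)n(C)c3n2)cnn1CC1(O)COC1`.

In an assay on isolated protein for inhibition of Leucine-rich repeat serine/threonine-protein kinase 2 variant G2019S (Homo sapiens), read by TR-FRET and LanthaScreen, with stated times of 50 min and 30 min, in the presence of a further agent that is not named here (a higher number here means a weaker inhibitor, a lower number a stronger inhibitor), compound 1 gives 25 nM, and compound 2 gives 10 nM. Compound 2 stands lowest of the two numbers; compound 1 sits one step beyond the scatter above it. Compound 3 `Cc1c(Nc2nc(N)c3c(C#N)c(N4CCC[C@H]4C)n(C)c3n2)cnn1C1COC1` differs from compound 2 by oxetan-3-yl in place of (3-hydroxyoxetan-3-yl)methyl on an aromatic nitrogen. Within the data shown here, no pair of measured compounds that differ in one place is available to size this change, so the step from compound 2 to compound 3 is expected to be a 2.0-fold higher number from compound 2 to compound 3 (0.30 log units; within the scatter), a small rise beyond the scatter at most. Compound 3 is expected at 20 nM, with a range of 8 nM to 50 nM.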

Compound 3, half-maximal inhibitory concentration: 37 nM
Compound 3: middle estimate off by 1.9-fold (0.27 log units), on the low side; the measured number falls inside the stated range.
By their numbers in this assay, from the lowest: compound 2; then compounds 1 and 3 (each within the scatter of the next).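

Replacing (3-hydroxyoxetan-3-yl)methyl with oxetan-3-yl on the aromatic nitrogen gives a 3.7-fold higher number from compound 2 to compound 3 (0.57 log units; beyond the scatter) in this assay, so the group at this position registers in the read-out. Exchanging 3-methyl-1-(oxetan-3-yl)-1H-pyrazol-4-yl for its 5-methyl isomer gives a 1.5-fold higher number from compound 1 to compound 3 (0.17 log units; within the scatter), so this pair is not told apart. Nothing available explains either step.

The change from compound 2 to compound 3 removes the hydroxy group and the methylene link together, leaving their separate shares open. As far as these compounds go, how a plain oxetan-3-ylmethyl or an aminomethyl group would read at this nitrogen also stays open.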